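This account rests on a few compounds, and the source may have more. Where it says the series, first, only, none or still open, it means among the compounds named here.

Measured compounds in a functional assay on SW-620 cells (Homo sapiens) for cytotoxicity, read by MTT assay, with a stated time of 72 h; a lower number here means a stronger inhibitor, a higher number a weaker inhibitor:
compound 1 `COc1cccc(/C=C2\CCC/C(=C\c3ccc(Cl)cc3)C2=O)c1OC` gives 11100 nM
compound 2 `COc1cccc(/C=C2\CCC/C(=C\c3cccc(OC)c3OC)C2=O)c1` gives 7000 nM
compound 3 `COc1cccc(/C=C2\CCC/C(=C\c3ccc(Cl)c(Cl)c3)C2=O)c1OC` gives 10000 nM

Compound 1 has the highest of the three numbers in this assay, but its steps to the other two are both within the scatter: a 1.1-fold lower number from compound 1 to compound 3 (0.05 log units; within the scatter) and a 1.6-fold lower number from compound 1 to compound 2 (0.20 log units; within the scatter). The step between the other two is likewise small, a 1.4-fold higher number from compound 2 to compound 3 (0.15 log units; within the scatter). On these numbers the three compounds are not separated.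

Compound 4 `COc1cccc(/C=C2\CCC/C(=C\c3cc(Cl)cc(Cl)c3)C2=O)c1OC` is not yet measured. It differs from compound 1 as follows: 3,5-dichlorophenyl in place of 4-chlorophenyl on a double-bonded chain carbon bound to a double-bonded ring carbon. The step that bears most directly on it is the one in which a chlorine is added to the same aryl group, a 1.1-fold lower number from compound 1 to compound 3 (0.05 log units; within the scatter); a second chlorine on the ring in compound 3 left the number where it was. The exchange of the whole aryl group, a 1.6-fold lower number from compound 1 to compound 2 (0.20 log units; within the scatter), also stayed within the scatter. Among the compounds with values here, no step across the series has moved the number beyond the scatter, so for compound 4 no step beyond the scatter is expected in this assay, in either direction. Compound 4 is therefore expected to give about 10000 nM, with a range of 5000 nM to 20000 nM, which means an expected step of a 1.1-fold lower number from compound 1 to compound 4 (0.05 log units; within the scatter).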

Compound 4, half-maximal inhibitory concentration: 5500 nM
Compound 4: the middle estimate sits 1.8-fold (0.26 log units) above what was measured, and the stated range covers the measured number.
By their numbers in this assay, from the lowest: compounds 4, 2, 3 and 1 (each within the scatter of the next).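

Within the data shown here, the 3,5-dichlorophenyl group at this place, on a double-bonded chain carbon bound to a double-bonded ring carbon, gives the largest step so far in this assay (a 2.0-fold lower number from compound 1 to compound 4 (0.30 log units; within the scatter)), yet that step stays within the scatter. Its steps against the other two aryl groups also stay within the scatter (a 1.8-fold lower number from compound 3 to compound 4 (0.26 log units; within the scatter)) and (a 1.3-fold lower number from compound 2 to compound 4 (0.10 log units; within the scatter)), so moving the chlorines around this aryl group does not separate the compounds, and 3-methoxyphenyl does not separate from them either. No measurement shown accounts for these numbers.

On these data alone, whether a different kind of group on this aryl ring, such as an amine or a carboxylic acid, would move the number beyond the scatter stays open. Also open, as far as these compounds go, is whether the four compounds remain unseparated in any other assay.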